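Compound 3: one chloro in place of hydrogen

The source may report more compounds than this note shows. Statements on the series, on what has been measured and on what is new or still open speak of the compounds shown alone.

Measured so far in a functional assay on MT4 cells (Homo sapiens), read by MTT assay; on this read-out higher numbers stand for lower toxicity in this test and lower numbers for higher toxicity in this test:
Compound 1 `C#C[C@]1(CO)OC(N2C=C(C)C(O)NC2=O)[C@@H](O)[C@@H]1O`: > 350000 nM
Compound 2 `C#C[C@]1(CO)O[C@@H](n2ccc(=O)[nH]c2=O)C[C@@H]1O`: > 100000 nM

Compound 2 stands at > 100000 nM, which is a limit and not a number. Compound 1 also gives only a limit, at > 350000 nM. Compound 3 `C#C[C@]1(CO)O[C@@H](n2cc(Cl)c(=O)[nH]c2=O)C[C@@H]1O` has chloro in place of hydrogen on an aromatic carbon of compound 2 (chloro in place of hydrogen on an aromatic carbon). Going by the values given here, no measured pair shows what this change does. In this assay, the expected a number no higher from compound 2 to compound 3 (the limit leaves the size open) stays within the scatter, with no direction foreseen. Compound 3 is estimated at 100000 nM, with an expected range of 30000 nM to 350000 nM.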

Compound 3, half-maximal cytotoxic concentration: 81700 nM
For compound 3 the middle estimate is 1.2-fold (0.09 log units) above the measured one; the measured number falls inside the stated range.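

Going by these compounds alone, with chloro on this aromatic carbon, compound 3 gives the first actual number in this assay, where the earlier compounds gave only limits. The change gives an at least 1.2-fold lower number from compound 2 to compound 3 (0.08 log units; that floor lies within the scatter), so this position tolerates chloro without a step beyond the scatter being shown. The full size of the step stays unknown, since its starting point is only a limit: the limit of > 100000 nM in this assay, at which 1 of the 3 values shown sits.

As far as these compounds go, what a bromo, a methyl or an amine on the same aromatic carbon would give remains open. So does whether chloro would act alike on the core of compound 1.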